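The compounds below may be only part of what the source reports. "The series", "measured", "known", "first", "only" and "open" are said of these compounds alone.

Measured compounds:
Compound 1, `OC(c1ccccc1)(c1ccccc1)c1ccccc1Cl`: 2100 nM
Compound 2, `O=[N+]([O-])c1ccc(C(O)(c2ccccc2)c2ccccc2)c(Cl)c1`: 300 nM
Compound 3, `OC(Cc1ccccc1)(c1ccccc1)c1ccccc1`: 400 nM; 400 nM (2 entries); 400 nM; 400 nM (2 entries)

Compound 1 stands at the weaker end of the numbers available in a functional assay on NIH3T3 cells (Mus musculus) for antiproliferative activity; a higher number here means a weaker inhibitor, a lower number a stronger inhibitor. Compound 1 gives the highest number in this assay, and its nearest neighbour is compound 2, which differs from it by a nitro in place of hydrogen on an aromatic carbon and gives a 7.0-fold lower number from compound 1 to compound 2 (0.85 log units; beyond the scatter). Among the measured compounds shown here, compound 3 shares the tertiary alcohol with compound 1 but is arranged differently, and for that pair no single step has been counted; the two values simply show compound 3 at a lower number than compound 1.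

The compound not yet measured is compound 4, `OC(c1ccccc1)(c1ccccc1)c1ccc(Cl)cc1`. It differs from compound 1 as follows: 4-chlorophenyl in place of 2-chlorophenyl on a saturated chain carbon bound to two aromatic carbons and an oxygen on a saturated carbon. For the measured compounds named here, no measured step in this assay moves a chlorine from one ring position to another, so none of the steps on hand bears directly on this change. Going by the values given here, the only measured step from compound 1 is the nitro step to compound 2, which concerns a different part of the molecule. Among the compounds with values here, the change from compound 1 to compound 4 therefore has no close precedent here, and the expected step is small, within or only just beyond the scatter, with no clear direction.

Compound 4 is expected to give about 1500 nM, with a plausible range from 400 nM to 5000 nM. That estimate means a step of a 1.4-fold lower number from compound 1 to compound 4 (0.15 log units; within the scatter), which is expected to stay close to the scatter.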

Compound 4, half-maximal inhibitory concentration: 800 nM
Estimate against measurement, compound 4: 1.9-fold (0.27 log units) above; measured number inside the range.
By their numbers in this assay, from the lowest: compound 2; then compound 4; then compound 1.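

In this assay, the exchange of 2-chlorophenyl for 4-chlorophenyl on the saturated chain carbon gives a 2.6-fold lower number from compound 1 to compound 4 (0.42 log units; beyond the scatter), so the place of the chlorine on this ring matters even though nothing is added or removed. The earlier step, a 7.0-fold lower number from compound 1 to compound 2 (0.85 log units; beyond the scatter), showed a change in the number only when a nitro group was added to the ring. This new step shows that the same atoms, joined differently, also move the result beyond the scatter, and the chlorine therefore cannot be treated as interchangeable between these two ring places. Nothing available here accounts for the lower number of compound 4, so the finding remains an observation about these two compounds alone.

The compounds shown leave open whether adding a nitro group to the 4-chlorophenyl ring of compound 4 would lower the number as it did for compound 1. They also leave open how an amine or a carboxylic acid in place of the chlorine would compare, and whether either would follow the same dependence on ring place.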